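Swapping a Piperidinyl Group for Fluorine at One Position

The compounds below may be only part of what the source reports. "The series", "measured", "known", "first", "only" and "open" are said of these compounds alone.

Of the compounds shown here, three built on one shared core have been measured in an assay on isolated protein for binding affinity to corticotropin-releasing factor receptor 1 (Homo sapiens); a higher number here means a weaker inhibitor, a lower number a stronger inhibitor. Compound 1 `CCCN(CCC)c1cc(C)nc2c(-c3ncc(C(F)(F)F)cc3Cl)c(C)nn12` gives 1.2 nM. Compound 2 `CCCN(CCC)c1cc(C)nc2c(-c3ncc([N+](=O)[O-])cc3C)c(C)nn12` gives 9.1 nM, and compound 3 `CCCN(CCC)c1cc(C)nc2c(-c3ncc(N4CCCCC4)cc3C)c(C)nn12` gives 17 nM. Compound 3 therefore has the highest of the three numbers. Going by the values given here, its nearest neighbour is compound 2: the only single-point step measured so far is a 1.9-fold higher number from compound 2 to compound 3 (0.27 log units; within the scatter), in which piperidin-1-yl replaced nitro on an aromatic carbon. Compound 1, which carries a different pair of substituents on the same ring, gives a far lower number than compound 3, beyond the scatter.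

Compound 4 `CCCN(CCC)c1cc(C)nc2c(-c3ncc(F)cc3C)c(C)nn12` differs from compound 3 in one place: fluoro in place of piperidin-1-yl on an aromatic carbon. Among the compounds with values here, no measured step exchanges piperidin-1-yl for fluoro, so the expectation rests on indirect evidence. The step of a 1.9-fold higher number from compound 2 to compound 3 (0.27 log units; within the scatter) shows that changing the group on this carbon moved the number only within the scatter, while compound 1 shows that this ring tolerates small substituents with a low number. For compound 4 the expected step is a 3.4-fold lower number from compound 3 to compound 4 (0.53 log units; beyond the scatter), a modest move toward a lower number. Compound 4 is therefore estimated to give about 5 nM, most likely between 1.5 nM and 20 nM.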

Compound 4, inhibition constant: 19 nM
Compound 4: middle estimate off by 3.8-fold (0.58 log units), on the low side; low and high end bracket the measured number.
By their numbers in this assay, from the lowest: compound 1; then compounds 2, 3 and 4 (each within the scatter of the next, the first and the last beyond it).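

In this assay, replacing piperidin-1-yl with fluoro gives a 1.1-fold higher number from compound 3 to compound 4 (0.05 log units; within the scatter), so at this carbon, two atoms from the ring nitrogen, a ring of 6 heavy atoms and a single fluorine atom cannot be told apart. Going by these compounds alone, replacing nitro with fluoro gives a 2.1-fold higher number from compound 2 to compound 4 (0.32 log units; beyond the scatter), a modest step that only just passes the scatter, and it is the one change at this carbon so far to do so, since the step from nitro to piperidin-1-yl stays within it. Among compounds 2, 3 and 4, then, three very different groups at this carbon give numbers that lie close together, and no measurement at hand accounts for this.

Compound 1 differs from compounds 2, 3 and 4 in two places at once, so the compounds shown cannot say whether its lower number goes with trifluoromethyl at this carbon or with chloro in place of the methyl group. Also open, as far as these compounds go, is how the number would respond to an amine, a carboxylic acid or a methoxy group at this carbon, with the methyl group kept in place.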